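Chloro in place of hydrogen: compound 2 to compound 4

A few compounds are considered here, and "the series" means these few. Any claim that something is new, unique, unknown or untested is made for them only; others in the source may bear on it.

Compound 2 `COc1c(/C=C2/C(=O)Nc3ccccc32)c2ccccc2n1-c1ccccc1` gives 3980 nM in a functional assay on cells (Melanoma cell, Homo sapiens) for cytotoxicity, with a stated time of 48 h (a higher number here means a weaker inhibitor of growth, a lower number a stronger inhibitor of growth), the lowest of the three numbers available. The nearest neighbour of compound 2 is compound 1 `COc1cc2c(/C=C3/C(=O)Nc4ccc(Cl)cc43)c(Cl)n(Cc3cc(OC)c(OC)c(OC)c3)c2cc1C`, which gives 5750 nM in this assay, a gap within the scatter. Compound 3 `COc1ccc2c(c1)/C(=C\c1c(Cl)n(Cc3cc(OC)c(OC)c(OC)c3)c3cc(C)c(OC)cc13)C(=O)N2` is furthest, giving 75900 nM in this assay. Compound 4 `COc1c(/C=C2/C(=O)Nc3ccc(Cl)cc32)c2ccccc2n1-c1ccccc1` differs from compound 2 by chloro in place of hydrogen on an aromatic carbon.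

For the measured compounds named here, only one measured step touches this place on the ring: a 13-fold higher number from compound 1 to compound 3 (1.12 log units; beyond the scatter), where the chloro of compound 1 was swapped for methoxy. Going by the values given here, that step says chloro fares better than methoxy at this place, but no measured pair compares chloro with hydrogen there, and compounds 1 and 3 share a core that compound 2 does not. The expectation for compound 4 is therefore a step of a 1.3-fold lower number from compound 2 to compound 4 (0.12 log units; within the scatter) in this assay, a modest move toward a lower number that stays within the scatter. Compound 4 is estimated at 3000 nM in this assay, with a range from 1000 nM to 10000 nM.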

Compound 4, concentration for total growth inhibition: 18200 nM
Beside the measured number, compound 4's estimate is 6.1-fold (0.78 log units) below it; the whole stated range lies below it.
By their numbers in this assay, from the lowest: compounds 2 and 1 (each within the scatter of the next); then compound 4; then compound 3.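

In this assay, chloro in place of hydrogen on this aromatic carbon gives a weaker inhibitor of growth, with a 4.6-fold higher number from compound 2 to compound 4 (0.66 log units; beyond the scatter), a change beyond the scatter. For the compounds shown here, this is the first direct reading of chloro against hydrogen at this place, since the earlier step, a 13-fold higher number from compound 1 to compound 3 (1.12 log units; beyond the scatter), set chloro only against methoxy and on a different core, so chloro faring better there does not carry over to a comparison with hydrogen. Nothing available on these compounds accounts for the loss.

From the compounds shown here alone, whether hydrogen would also beat chloro on the core of compound 1 remains open, so the two steps give no single order of hydrogen, chloro and methoxy. Going by these compounds, how fluoro, an amine or a carboxylic acid would fare at this place also remains unknown.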